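Swapping phenyl for furan-2-yl in compound 3

A few compounds are considered here, and "the series" means these few. Any claim that something is new, unique, unknown or untested is made for them only; others in the source may bear on it.

Measured in a functional assay on NCI-H460 cells (Homo sapiens) for cytotoxicity, read by MTT assay, with a stated time of 72 h; on this read-out lower numbers stand for stronger inhibition and higher numbers for weaker inhibition:
Compound 1 `O=c1[nH]/c(=C\c2nc[nH]c2C2CC2)c(=O)[nH]/c1=C\c1cccc(Oc2ccc(F)cc2)c1`: 15.2 nM.
Compound 2 `O=c1[nH]/c(=C\c2cccc(Oc3ccc(F)cc3)c2)c(=O)[nH]/c1=C\c1cccnc1`: > 1000 nM, which is a limit of the assay and not a number.
Compound 3 `O=c1[nH]/c(=C\c2cccc(Oc3ccc(F)cc3)c2)c(=O)[nH]/c1=C\c1ccccc1`: 389 nM.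

Compound 3 holds the higher of the two exact numbers. Compound 4 `O=c1[nH]/c(=C\c2ccco2)c(=O)[nH]/c1=C\c1cccc(Oc2ccc(F)cc2)c1` differs from it by one group (furan-2-yl in place of phenyl on a double-bonded chain carbon bound to an aromatic carbon). Within the data shown here, three measured steps concern this same place: a 26-fold higher number from compound 1 to compound 3 (1.41 log units; beyond the scatter), an at least 65-fold higher number from compound 1 to compound 2 (1.81 log units; beyond the scatter) and an at least 2.5-fold lower number from compound 2 to compound 3 (0.41 log units; beyond the scatter). All lie beyond the scatter, so the place is sensitive and the range must be wide. Furan-2-yl is closer to the plain rings of compound 2 and compound 3 than to the 5-cyclopropyl-1H-imidazol-4-yl of compound 1, so a drop as large as the one separating compound 3 from compound 1 is not expected. The expected change is small, a 1.3-fold lower number from compound 3 to compound 4 (0.11 log units; within the scatter), and is estimated to stay within the scatter. For compound 4 the estimated value in this assay is 300 nM, with an expected range of 80 nM to 1000 nM.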

Compound 4, half-maximal inhibitory concentration: 155 nM
Compound 4: the middle estimate sits 1.9-fold (0.29 log units) above what was measured, within the range that was stated.
By their numbers in this assay, from the lowest: compound 1; then compound 4; then compound 3. At a limit, above all of these: compound 2.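

Five-membered furan-2-yl, with its one hydrogen-bond acceptor, improves on six-membered phenyl at this place, giving a 2.5-fold lower number from compound 3 to compound 4 (0.40 log units; beyond the scatter), so even a change between two small uncharged aromatic rings registers here. Furan-2-yl also gives an at least 6.4-fold lower number from compound 2 to compound 4 (0.80 log units; beyond the scatter) against pyridin-3-yl, yet it falls short of 5-cyclopropyl-1H-imidazol-4-yl, with a 10-fold higher number from compound 1 to compound 4 (1.01 log units; beyond the scatter). The step from compound 2 rests on a limit of the assay and not a number: the limit of > 1000 nM in this assay, at which 1 of the 4 values shown sits.

Still open, from the compounds shown here alone, is whether the ring oxygen or the smaller ring matters more, which thiophen-2-yl could help to test. Also open, going by these compounds, is how a plain 1H-imidazol-4-yl, lacking the cyclopropyl, would compare.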